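The source may report more compounds than this note shows. Statements on the series, on what has been measured and on what is new or still open speak of the compounds shown alone.

Series notes, a functional assay on T47D cells (Homo sapiens) for antiproliferative activity, read by MTT assay, with a stated time of 72 h; a higher number here means a weaker inhibitor, a lower number a stronger inhibitor:

- compound 1 `O=C(Nc1ccc(Cl)c(-c2nnc3c(Cl)cccn23)c1)c1ccccc1`: > 100000 nM, a limit of the assay
- compound 2 `O=C(Nc1ccc(Cl)c(-c2nnc3c(Cl)cccn23)c1)c1cccc(Cl)c1`: 30200 nM
- compound 3 `O=C(Nc1ccc(Cl)c(-c2nnc3c(Cl)cccn23)c1)c1c(F)cccc1Cl`: > 100000 nM, a limit of the assay

Compound 3 stands at the limit; the limit of > 100000 nM in this assay, at which 2 of the 3 values shown sit, makes its place in the order unreadable. Against compound 2 the step is readable: an at least 3.3-fold higher number from compound 2 to compound 3 (0.51 log units; beyond the scatter). The step that the two limits leave unreadable from compound 1 to compound 3 cannot be sized, both ends being limits. Among the compounds with values here, the only fully numbered step, an at least 3.3-fold lower number from compound 1 to compound 2 (0.51 log units; beyond the scatter), shows that a chloro on the benzamide ring can bring the number down from the limit.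

Compound 4 `O=C(Nc1ccc(Cl)c(-c2nnc3c(Cl)cccn23)c1)c1ccccc1Cl` differs from compound 3 by hydrogen in place of fluoro on an aromatic carbon, giving a 2-chlorophenyl amide. Compound 1 without any chloro sits at the limit, compound 2 with a chloro sits below it, and compound 3 with two halogens again sits at the limit, so the chloro alone in compound 4 is expected to leave it weak, at or a little under the limit. The expected step is an at least 1.4-fold lower number from compound 3 to compound 4 (0.15 log units; that floor lies within the scatter). For compound 4 the estimate in this assay is 70000 nM, between 25000 nM and 200000 nM.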

Compound 4, half-maximal inhibitory concentration: 83800 nM
Compound 4: the middle estimate sits 1.2-fold (0.08 log units) below what was measured; measured number inside the range.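

Shifting the chloro from the 3-chlorophenyl amide to the 2-chlorophenyl amide weakens the compound in this assay, giving a 2.8-fold higher number from compound 2 to compound 4 (0.44 log units; beyond the scatter). Within the data shown here, in this pair, the placing of the single chloro on the benzamide ring therefore matters, which the earlier compounds did not show. Hydrogen in place of fluoro gives an at least 1.1-fold lower number from compound 3 to compound 4 (0.07 log units; that floor lies within the scatter), and chloro in place of hydrogen gives an at least 1.1-fold lower number from compound 1 to compound 4 (0.07 log units; that floor lies within the scatter); both floors lie within the scatter, so neither step shows a real change.

Going by these compounds, the true size of these two steps stays unread, as each starts from a compound resting on a limit: the limit of > 100000 nM in this assay, at which 2 of the 4 values shown sit. Whether an amine, a methoxy group or a carboxylic acid in place of the chloro of the 3-chlorophenyl amide would bring the number lower also stays open.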